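A few compounds are considered here, and "the series" means these few. Any claim that something is new, unique, unknown or untested is made for them only; others in the source may bear on it.

Working notes on the series. Among the compounds with values here, the two measured members share one core with a cyclopropyl-bearing amide side chain and differ only in the amino-acid part. Compound 1 `C[C@H](NC(=O)CN(c1nc(Cl)nc2[nH]cnc12)C1CC1)C(=O)O` carries a 1-carboxyethyl group on the amide nitrogen; compound 2 `NC(=O)C[C@H](NC(=O)CN(c1nc(Cl)nc2[nH]cnc12)C1CC1)C(=O)OCc1ccccc1` carries an asparagine-derived benzyl ester instead. In a functional assay on the whole organism (Tail, strain ICR) with Mus musculus as the target, in the tail flick test, with a stated time of 150 min, at a dose of 25 umol/kg by the oral route (a lower number here means a weaker effect, a higher number a stronger effect of the compound at the dose given), compound 1 gives 14.7%, and compound 2 gives 13.5% in this assay; the two values lie within the scatter of each other, so no order between them can be read, and both show only a weak effect at the dose used.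

Compound 3 `O=C(O)CNC(=O)CN(c1nc(Cl)nc2[nH]cnc12)C1CC1` is the next member, not yet measured in this assay. It differs from compound 1 in one place: hydrogen in place of methyl on a saturated chain carbon bound to an amide-type nitrogen and a carbonyl carbon. Within the data shown here, with only two weak values in hand and no measured step of this kind, a step beyond the scatter is not expected; the step from compound 1 to compound 3 is estimated at a number 1.7 percentage points lower from compound 1 to compound 3 (within the scatter). Compound 3 is therefore expected to give about 13% in this assay, within 4% to 24%.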

Compound 3, a percentage reported as activity, at one dose (the size of the read-out at that dose, not a potency): 9.08%
The estimate for compound 3 lay 3.9 percentage points above the measured number, and the stated range covers the measured number.
By their numbers in this assay, from the lowest: compounds 3, 2 and 1 (each within the scatter of the next).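

In this assay, hydrogen in place of methyl on the saturated chain carbon bound to an amide-type nitrogen and a carbonyl carbon, which turns 1-carboxyethyl into carboxymethyl, gives a number 5.6 percentage points lower from compound 1 to compound 3 (within the scatter). Within the data shown here, this is the first step read at this position, and it shows that, at this dose, the read-out does not separate methyl from hydrogen here beyond the usual scatter. No supporting data bear on this result.

Still open, as far as these compounds go, is whether a larger group at this carbon, such as an isobutyl chain, or a group of another kind, such as an aminomethyl group, would give a step beyond the scatter. Also open, from the compounds shown here alone, is whether the methyl-to-hydrogen step stays within the scatter at other doses or times.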